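Working notes: pyrazolyl ester in place of hydroxyethoxyphenyl

This account rests on a few compounds, and the source may have more. Where it says the series, first, only, none or still open, it means among the compounds named here.

Measured so far:
compound 1 `COc1ncc(-c2ccc3ncnc(Nc4ccc(OCCO)cc4)c3c2)cc1NS(=O)(=O)c1ccc(F)cc1F` gives 1060 nM
compound 2 `COc1ncc(-c2ccc3ncnc(Nc4cnn(CCC(=O)O)c4)c3c2)cc1NS(C)(=O)=O` gives 1290 nM
compound 3 `CCCCS(=O)(=O)Nc1cc(-c2ccc3ncnc(Nc4ccc(OCCO)nc4)c3c2)cnc1OC` sits at a limit, > 20000 nM

In a functional assay on HCT-116 cells (Homo sapiens) for antiproliferative activity, read by sulforhodamine B assay, with a stated time of 72 h (a lower number here means a stronger inhibitor, a higher number a weaker inhibitor), compound 1 gives 1060 nM, the lowest of the two numbers shown; compound 2, with 1290 nM, lies within the scatter of compound 1, so no order between the two is claimed. Compound 3 stands at the limit of > 20000 nM in this assay, at which 1 of the 3 values shown sits, and contributes no number.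

Compound 4 `COC(=O)Cn1cc(Nc2ncnc3ccc(-c4cnc(OC)c(NS(=O)(=O)c5ccc(F)cc5F)c4)cc23)cn1` is not yet measured. It differs from compound 1 by 1-((methoxycarbonyl)methyl)-1H-pyrazol-4-yl in place of 4-(2-hydroxyethoxy)phenyl on a nitrogen on an aromatic ring. For the measured compounds named here, no step between measured compounds covers this change directly. Compound 2, which carries a pyrazolyl group bearing an acid chain on the same nitrogen together with a methylsulfonamide, gives a number within the scatter of compound 1, whereas compound 4 keeps the difluorophenylsulfonamide of compound 1 and carries the ester chain on the pyrazole. On that basis the expected step from compound 1 to compound 4 is a 1.4-fold lower number from compound 1 to compound 4 (0.15 log units; within the scatter), that is none beyond the scatter, with at most a slight tilt toward a lower number. Compound 4 is therefore estimated at 750 nM, with a range from 200 nM to 2800 nM.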

Compound 4, half-maximal inhibitory concentration: 1260 nM
Compound 4: middle estimate off by 1.7-fold (0.23 log units), on the low side, and the stated range covers the measured number.
By their numbers in this assay, from the lowest: compounds 1, 4 and 2 (each within the scatter of the next). At a limit, above all of these: compound 3.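

In this assay, 1-((methoxycarbonyl)methyl)-1H-pyrazol-4-yl in place of 4-(2-hydroxyethoxy)phenyl gives a 1.2-fold higher number from compound 1 to compound 4 (0.08 log units; within the scatter). For the compounds shown here, this is the one direct reading at this position, and with the difluorophenylsulfonamide held constant, it shows that a five-membered aromatic ring with 2 hetero atoms and no hydrogen-bond donor reads the same, within the scatter, as the six-membered carbon ring with its hydroxyethoxy chain. Nothing measured here gives a reason for this step.

On these data alone, whether the methyl ester contributes at all remains open, since a primary amide or a dimethylamino group on the pyrazole chain has no reading here. A carboxylic acid chain on the pyrazole of compound 4 also has no reading alongside the difluorophenylsulfonamide.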